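This account rests on a few compounds, and the source may have more. Where it says the series, first, only, none or still open, it means among the compounds named here.

Of the compounds shown here, three sharing one core have been tested in a functional assay on NCI-H322M cells (Homo sapiens) for inhibition, read by sulforhodamine B assay, with a stated time of 48 h; on this read-out lower numbers stand for higher toxicity in this test and higher numbers for lower toxicity in this test. Compound 1 `Nc1cc(N)c2nc(-c3ccccc3)c(NCc3ccc(Cl)c(Cl)c3)nc2c1` gives 69200 nM. Compound 2 `Nc1cc(N)c2nc(-c3ccccc3)c(Sc3ccc(F)cc3)nc2c1` gives 70800 nM, the highest of the two numbers, and compound 1 sits within the scatter of it. For compound 3 `COc1cc(CNc2nc3cc(N)cc(N)c3nc2-c2ccccc2)cc(OC)c1OC` this assay reports only a limit, < 50200 nM. Compound 4 `Nc1cc(N)c2nc(-c3ccccc3)c(Sc3ccc(Cl)c(Cl)c3)nc2c1` is not yet measured; it differs from compound 2 by 3,4-dichlorophenyl in place of 4-fluorophenyl on a sulfur. For the measured compounds named here, no measured pair differs in one place only, so no step has been observed. With compound 1 and compound 2 within the scatter of each other, the change is expected to shift this assay at most slightly, toward a lower number. Compound 4 is estimated at 60000 nM, between 30000 nM and 120000 nM. That expectation corresponds to a 1.2-fold lower number from compound 2 to compound 4 (0.07 log units; within the scatter).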

Compound 4, concentration lethal to 50% of the cells: < 100000 nM
Compound 4: no number, only a limit; the forecaster's own chance of this, stated with the estimate: 20%; the middle value lies beyond the limit too.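

In this assay compound 4 gives < 100000 nM which is a limit and not a number, so the step from compound 2 to compound 4 cannot be read. From the compounds shown here alone, whether 3,4-dichlorophenyl in place of 4-fluorophenyl on a sulfur changes the toxicity read-out at all, and in which direction, stays open.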